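Swapping one ring on a shared core

The source may hold more compounds than are shown below. What is called first, only, known or untested is meant among the compounds shown, and "the series" means these compounds.

- compound 1 `Cc1cc(C)c(-c2cn(C)cn2)cc1NC(=O)c1ccc(OCc2ccccn2)cc1` with 0.055 as its value
- compound 2 `Cc1ccc(-c2ncc[nH]2)c(C)c1NC(=O)c1ccc(OCc2ccccn2)cc1` with 0.09 as its value

Only these two compounds have been measured so far in an ADME assay on a cell-free system (plasma, Homo sapiens) for protein binding (on this read-out higher numbers stand for a larger free fraction and lower numbers for a smaller free fraction), on this scale. Compound 1 stands at 0.055 and compound 2 at 0.09 in the same test, two numbers that lie within the usual scatter of each other.

Compound 3 `Cc1cc(C)c(-c2c[nH]nc2C)cc1NC(=O)c1ccc(OCc2ccccn2)cc1` keeps the core of compound 1 and alters a single group: 3-methyl-1H-pyrazol-4-yl in place of 1-methyl-1H-imidazol-4-yl on an aromatic carbon.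

Within the data shown here, no measured pair shows what this swap does, so the closeness of the two known values is the only guide. The expected change is none beyond the scatter, with a 1.1-fold lower number from compound 1 to compound 3 (0.04 log units; within the scatter) as the estimated step here. Compound 3 is estimated at 0.05 within an expected range (0.025 to 0.1).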

Compound 3, unbound fraction: 0.021
For compound 3 the middle estimate is 2.4-fold (0.38 log units) above the measured one; the measured number lies below the stated range.
By their numbers in this assay, from the lowest: compound 3; then compounds 1 and 2 (each within the scatter of the next).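

In this assay this swap gives a 2.6-fold lower number from compound 1 to compound 3 (0.42 log units; beyond the scatter), so the position is sensitive to more than the size and atom count of the ring. The two groups have the same heavy atoms and both form a five-membered aromatic ring with 2 hetero atoms, yet the way those atoms are joined still moves the free fraction beyond the scatter. Nothing measured here accounts for the change.

These compounds cannot separate the gain of a hydrogen-bond donor from the change in where the methyl group sits, as both arrive in the same swap. Also open, from the compounds shown here alone, is how the free fraction would respond at this position to a group of a different kind, such as an amine or a carboxylic acid.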